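Unbound Fraction After Exchange of a Ring Substituent

A few compounds are considered here, and "the series" means these few. Any claim that something is new, unique, unknown or untested is made for them only; others in the source may bear on it.

Measured compounds:
Compound 1 `CCCCN(c1nc2ccccc2o1)[C@H](C)c1ccc(-c2ccccc2-c2nnn[nH]2)cc1`: 0.000713
Compound 2 `CCCCN(c1nc2c(NS(C)(=O)=O)cccc2o1)[C@H](C)c1ccc(-c2ccccc2-c2nnn[nH]2)cc1`: 0.000203

Of the compounds shown here, two sharing one core have been measured in an ADME assay on the whole organism (plasma, Macaca fascicularis) for protein binding, read by LC-MS, using equilibrium dialysis and cassette dosing, with a stated time of 24 h, at a dose of 1 mg/kg by the oral route; on this read-out lower numbers stand for a smaller free fraction and higher numbers for a larger free fraction. Within the data shown here, compound 1 `CCCCN(c1nc2ccccc2o1)[C@H](C)c1ccc(-c2ccccc2-c2nnn[nH]2)cc1` gives 0.000713, and compound 2 `CCCCN(c1nc2c(NS(C)(=O)=O)cccc2o1)[C@H](C)c1ccc(-c2ccccc2-c2nnn[nH]2)cc1` gives 0.000203; of the two numbers, compound 2 holds the lower, the only step measured being a 3.5-fold lower number from compound 1 to compound 2 (0.55 log units; beyond the scatter).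

Compound 3 `CCCCN(c1nc2c(C(=O)NC)cccc2o1)[C@H](C)c1ccc(-c2ccccc2-c2nnn[nH]2)cc1` carries methylcarbamoyl in place of methanesulfonamido on an aromatic carbon. Among the measured compounds shown here, no measured step covers this exact exchange. For the measured compounds named here, the one step that bears on it, a 3.5-fold lower number from compound 1 to compound 2 (0.55 log units; beyond the scatter), shows that a substituent at this aromatic carbon in place of hydrogen moved this assay by a modest amount. With a different substituent entering, a step of comparable or smaller size is expected, most plausibly toward the number of compound 1, so the expected step is a 1.6-fold higher number from compound 2 to compound 3 (0.20 log units; within the scatter). Compound 3 is therefore estimated at 0.00032, with a range from 0.00013 to 0.0008.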

Compound 3, unbound fraction: 0.000975
Estimate against measurement, compound 3: 3.0-fold (0.48 log units) below, outside the stated range (above it).
By their numbers in this assay, from the lowest: compound 2; then compounds 1 and 3 (each within the scatter of the next).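

In this assay this aromatic carbon proves to tell substituents apart: methylcarbamoyl in place of methanesulfonamido gives a 4.8-fold higher number from compound 2 to compound 3 (0.68 log units; beyond the scatter) and so lies beyond the scatter, although each group counts one hydrogen-bond donor and neither carries a net charge. Measured against hydrogen, the same group gives a 1.4-fold higher number from compound 1 to compound 3 (0.14 log units; within the scatter) and stays within the scatter, so among these compounds a substituent at this carbon does not by itself lower the number, and only methanesulfonamido does so. Nothing available here accounts for the difference between the two groups.

From the compounds shown here alone, whether an amine or a carboxylic acid at this carbon would read like compound 3 or like compound 2 remains open. So does whether a longer chain on the sulfonyl or on the amide nitrogen would keep the gap between the two groups.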